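The source may hold more compounds than are shown below. What is called first, only, known or untested is meant among the compounds shown, and "the series" means these compounds.

Within the data shown here, compound 1 `COc1nc(-c2ccccn2)cc(-c2ccc(F)cc2)c1C#N` is one of two compounds measured in an assay on isolated protein for inhibition of sulfide:quinone oxidoreductase, mitochondrial (Homo sapiens) (on this read-out higher numbers stand for weaker inhibition and lower numbers for stronger inhibition), where compound 1 gives 14 nM. Compound 2 `COc1nc(-c2ncccc2C)cc(-c2ccc(F)cc2)c1C#N` gives 8.7 nM in this assay. Among the measured compounds shown here, the single measured step, a 1.6-fold lower number from compound 1 to compound 2 (0.21 log units; within the scatter), lies within the scatter, so compound 1 stands at the higher of the two numbers without any separation that could be called a real difference. Compound 3 `COc1nc(-c2ccccn2)cc(-c2ccc(F)cc2)c1C(N)=O` has not yet been measured in this assay; it differs from compound 1 by carbamoyl in place of cyano on an aromatic carbon. For the measured compounds named here, no measured step bears on this change: the only step known concerns a methyl in place of a hydrogen, a different kind of alteration, and it remained within the scatter. The expectation for compound 3 therefore rests on compound 1 alone, with 14 nM as the only anchor and a wide uncertainty around it. For compound 3 the expected step is a 2.9-fold higher number from compound 1 to compound 3 (0.46 log units; beyond the scatter), a move most likely toward a higher number whose size cannot be fixed from the data in hand. Compound 3 is thus expected to give 40 nM, with a range from 8 nM to 300 nM.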

Compound 3, half-maximal inhibitory concentration: 16200 nM
Compound 3: the middle estimate sits 410-fold (2.61 log units) below what was measured; the whole stated range lies below it.
By their numbers in this assay, from the lowest: compounds 2 and 1 (each within the scatter of the next); then compound 3.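

In this assay, among these compounds, the earlier compounds showed only a change elsewhere on the molecule, where a 1.6-fold lower number from compound 1 to compound 2 (0.21 log units; within the scatter), and gave no sign of how much the group ortho to the methoxy group and ortho to the 4-fluorophenyl group counts. Here a 1200-fold higher number from compound 1 to compound 3 (3.06 log units; beyond the scatter), so exchanging the nitrile for carbamoyl at this one position, with the rest of compound 1 unchanged, is enough to separate strong inhibition from weak inhibition on this read-out. Nothing at hand accounts for a step of this size.

The compounds shown leave open whether the nitrile is the only group that holds the low number at this position, or whether a bare hydrogen, a methyl group, a carboxylic acid, a methyl ester or an aminomethyl group would stand nearer to compound 1 or nearer to compound 3. They also leave open whether the same exchange of nitrile for carbamoyl would cost as much in compound 2, which carries the extra methyl group.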